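The source may report more compounds than this note shows. Statements on the series, on what has been measured and on what is new or still open speak of the compounds shown alone.

Three compounds of the series have been run in a functional assay on MT4 cells (Homo sapiens) for antiproliferative activity, read by MTT assay, with a stated time of 96 h; a higher number here means that more compound is needed for the effect, a lower number that less compound is needed. Compound 1 `N#C/C(=C\c1c(-c2ccccc2)[nH]c2ccccc12)C(=O)N1CCCCC1` gives 9600 nM. Compound 2 `N#C/C(=C\c1c(-c2ccccc2)[nH]c2ccccc12)C(=O)Nc1ccc(Cl)cc1` gives 1700 nM. Compound 3 `COCCOC(=O)/C(C#N)=C/c1c(-c2ccccc2)[nH]c2ccccc12` gives 1200 nM. The three differ only in the group on the carbonyl carbon. The step of a 5.6-fold lower number from compound 1 to compound 2 (0.75 log units; beyond the scatter) and the step of an 8.0-fold lower number from compound 1 to compound 3 (0.90 log units; beyond the scatter) both lie beyond the scatter, while the step of a 1.4-fold lower number from compound 2 to compound 3 (0.15 log units; within the scatter) lies within it. Compound 3 thus shows the lowest of the three numbers, though its distance to compound 2 is within the scatter and no order between those two can be read.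

Compound 4 `N#C/C(=C\c1c(-c2ccccc2)[nH]c2ccccc12)C(=O)c1ccccc1` is not yet measured. Its change from compound 3 is phenyl in place of 2-methoxyethoxy on a carbonyl carbon. All measured steps sit at this same carbonyl carbon: the two steps away from piperidin-1-yl were the larger ones, whereas the exchange of (4-chlorophenyl)amino for 2-methoxyethoxy stayed within the scatter. Phenyl matches none of the three groups measured, so the direction is open; a step within the scatter, or a modest rise, is expected, as a 1.5-fold higher number from compound 3 to compound 4 (0.18 log units; within the scatter). For compound 4 in this assay the estimate is 1800 nM, in a range from 500 nM to 7000 nM.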

Compound 4, half-maximal effective concentration: 500 nM
The estimate for compound 4 lay 3.6-fold (0.56 log units) above the measured number; the range from low to high includes it.
By their numbers in this assay, from the lowest: compound 4; then compounds 3 and 2 (each within the scatter of the next); then compound 1.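

Within the data shown here, with a 2.4-fold lower number from compound 3 to compound 4 (0.38 log units; beyond the scatter) and with a 3.4-fold lower number from compound 2 to compound 4 (0.53 log units; beyond the scatter) in this assay phenyl on this carbonyl carbon stands apart from 2-methoxyethoxy and (4-chlorophenyl)amino, two groups that the earlier compounds could not separate. Among these compounds, the span at this position widens to a 19-fold lower number from compound 1 to compound 4 (1.28 log units; beyond the scatter) and shows that the lowest number of the series so far comes with a group joined through carbon, not through the oxygen or nitrogen of the earlier compounds. No data at hand offer a reason for these steps.

From the compounds shown here alone, whether the lower number belongs to the aromatic ring or to the carbon link alone stays open, and a methyl or cyclohexyl on the same carbonyl carbon would separate the two. Going by these compounds, how a substituted ring such as 4-chlorophenyl or 4-methoxyphenyl would read in this position is also open.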